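From phenyl to 2,4-dimethoxyphenyl on a shared core

The source may report more compounds than this note shows. Statements on the series, on what has been measured and on what is new or still open speak of the compounds shown alone.

In an ADME assay on BHK-21 cells (Mesocricetus auratus) for cytotoxicity, read by MTT assay (on this read-out higher numbers stand for lower toxicity in this test and lower numbers for higher toxicity in this test), compound 2 (`C/C(=N\NC(N)=S)c1ccc2c(c1)nc(-c1ccccc1)n2C1CCCCC1`) gives 38000 nM as the higher of two measured numbers. Compound 1 (`COc1ccc(-c2nc3cc(C(C)=O)ccc3n2C2CCCCC2)c(OC)c1`) gives 8500 nM in the same test, and that gap lies beyond the usual scatter. These two compounds differ in more than one place, so their gap does not single out any one group. Compound 3 (`COc1ccc(-c2nc3cc(/C(C)=N/NC(N)=S)ccc3n2C2CCCCC2)c(OC)c1`) changes compound 2 in a single place, with 2,4-dimethoxyphenyl in place of phenyl on an aromatic carbon. For the measured compounds named here, no measured pair shows this swap alone. Going by the values given here, the only guide is compound 1, which also carries 2,4-dimethoxyphenyl and gives 8500 nM on the lower side. The expected step of a 1.9-fold lower number from compound 2 to compound 3 (0.28 log units; within the scatter) is therefore a modest one toward a lower number, within the usual scatter, and this estimate is uncertain. Compound 3 is expected at an estimated 20000 nM (range 6000 nM to 60000 nM).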

Compound 3, half-maximal cytotoxic concentration: 17000 nM
For compound 3 the middle estimate is 1.2-fold (0.07 log units) above the measured one, and the stated range covers the measured number.
By their numbers in this assay, from the lowest: compounds 1 and 3 (each within the scatter of the next); then compound 2.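

In this assay, the swap from phenyl to 2,4-dimethoxyphenyl on the aromatic carbon between two ring nitrogen atoms can now be read directly: a 2.2-fold lower number from compound 2 to compound 3 (0.35 log units; beyond the scatter), a modest shift toward higher toxicity in this test. With 2,4-dimethoxyphenyl held in place, exchanging the small carbonyl-bearing group of compound 1 for the longer nitrogen- and sulfur-containing group of compound 3 gives a 2.0-fold higher number from compound 1 to compound 3 (0.30 log units; within the scatter), so no difference between these two compounds can be claimed. Nothing here gives a measured reason for either step.

Going by these compounds, it remains open whether a single methoxy group on the phenyl ring, or a chlorine or an amine there, would shift the number in the same way. On these data alone, it is also open whether the step would hold with a smaller ring such as cyclopentyl in place of cyclohexyl.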